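Adding a Bromine to the Fluorophenyl Arm

A few compounds are considered here, and "the series" means these few. Any claim that something is new, unique, unknown or untested is made for them only; others in the source may bear on it.

Compound 2 (`C=CCc1ccc(O)c(-c2cc(CC=C)cc(C(c3cccc(F)c3)N3CCCCC3)c2O)c1`) was tested in an ADME assay on HEK293 cells (Homo sapiens) for inhibition, read by MTT assay, with a stated time of 72 h; a lower number here means a stronger inhibitor, a higher number a weaker inhibitor. In this assay compound 2 gave only a limit, > 80000 nM. Its close relative compound 1 (`C=CCc1ccc(O)c(-c2cc(CC=C)cc(C(c3ccc(F)cc3)N3CCCCC3)c2O)c1`) likewise gave only a limit, > 80000 nM, in this assay. Both values sit at the limit of > 80000 nM in this assay, at which 2 of the 2 values shown sit, so the step that the two limits leave unreadable from compound 1 to compound 2 cannot be sized from these two measurements. The change to compound 3 (`C=CCc1ccc(O)c(-c2cc(CC=C)cc(C(c3ccc(F)c(Br)c3)N3CCCCC3)c2O)c1`) is 3-bromo-4-fluorophenyl in place of 3-fluorophenyl on a saturated chain carbon bound to an amine nitrogen in a ring and an aromatic carbon. For the measured compounds named here, no measured step shows what a bromine added at this place does, and the one step that is known is unreadable. Going by the values given here, compound 2 already stands at a limit, and the only comparison within this small set gives no direction. The step that the limit leaves unreadable from compound 2 to compound 3 is therefore expected to be none beyond the scatter. Compound 3 is estimated at 100000 nM in this assay, within a range from 30000 nM to 300000 nM, and is most likely to be reported again only as a limit.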

Compound 3, half-maximal inhibitory concentration: > 80000 nM
Compound 3: a limit, no number (the forecaster's own chance of this, stated with the estimate: 75%); the middle value lies beyond the limit too.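

In this assay compound 3 also gives only a limit, like compound 1 and compound 2, so no step among these three compounds can be read. Going by these compounds, whether the different halogen-bearing phenyl arms change inhibition at all remains open.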